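The source may report more compounds than this note shows. Statements on the series, on what has been measured and on what is new or still open speak of the compounds shown alone.

Measured so far in a functional assay, tested at 100 ug/mL; on this read-out lower numbers stand for a weaker effect and higher numbers for a stronger effect at the one concentration tested:
Compound 1 `COc1ccc(C2=NN(c3ccccc3)C(c3ccc(C)cc3)C2S(=O)(=O)CC2=NCCO2)cc1` gives 67.7%.
Compound 2 `COc1ccc(C2=NN(c3ccccc3)C(c3ccc(C)cc3)C2S(=O)(=O)CC2=NCCS2)cc1` gives 47.9%.
Compound 3 `O=S(=O)(CC1=NCCS1)C1=NNCC1c1ccc(Cl)cc1` gives "not active" (no number reported).

Compounds 1 and 2 share one core and differ in a single place: a group of 5 heavy atoms (3 carbon, 1 nitrogen, 1 oxygen; one five-membered non-aromatic ring with 2 hetero atoms) in place of a group of 5 heavy atoms (3 carbon, 1 nitrogen, 1 sulfur; one five-membered non-aromatic ring with 2 hetero atoms), on a saturated chain carbon bound to a sulfonyl sulfur. That exchange gave a step of a number 19.8 percentage points higher from compound 2 to compound 1 (beyond the scatter). Compound 3 is built on a different core; the difference between the two cores is not broken down here. In this assay compound 3 gave no number at all, only the report "not active" (no number reported).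

Compound 4 `O=S(=O)(CC1=NCCO1)C1=NNCC1c1ccc(Cl)cc1` has not yet been measured. It stands to compound 3 exactly as compound 1 stands to compound 2: a group of 5 heavy atoms (3 carbon, 1 nitrogen, 1 oxygen; one five-membered non-aromatic ring with 2 hetero atoms) in place of a group of 5 heavy atoms (3 carbon, 1 nitrogen, 1 sulfur; one five-membered non-aromatic ring with 2 hetero atoms), on a saturated chain carbon bound to a sulfonyl sulfur. For the measured compounds named here, since the change and its place are the same, the one earlier step is the only guide to its size. That step was a modest one, and compound 3 starts from no measurable effect, so a modest rise from a very low level is expected, one that may well not lift compound 4 out of the range where only "not active" is reported.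

Compound 4 is expected to show about 15% in this assay, estimated between 0% and 40%.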

Compound 4, a percentage reported as activity, at one concentration (the size of the read-out at that concentration, not a potency): "not active" (no number reported)
Compound 4 has no reported number here, and the estimate cannot be compared.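

In this assay compound 3 and compound 4 are both reported only as "not active", without a number, so no new step can be read between them. No available evidence bears on this result. From the compounds shown here alone, it remains open whether the same ring exchange, which gave a number 19.8 percentage points higher from compound 2 to compound 1 (beyond the scatter) on the other core, has any effect on the core of compound 3.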